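Shortening the ester chain on the shared core

This account rests on a few compounds, and the source may have more. Where it says the series, first, only, none or still open, it means among the compounds named here.

Measured so far:
compound 1, `CCCCCCOc1ccc2c(=O)cc(-c3cc(C(C)(C)C)c(O)c(C(C)(C)C)c3)oc2c1`, 5000 nM in a functional assay for inhibition; a higher number here means a weaker inhibitor, a lower number a stronger inhibitor
compound 2, `COc1ccc2c(=O)cc(-c3cc(C(C)(C)C)c(O)c(C(C)(C)C)c3)oc2c1`, 1000 nM
compound 3, `CCCCCOC(=O)COc1ccc2c(=O)cc(-c3cc(C(C)(C)C)c(O)c(C(C)(C)C)c3)oc2c1`, 5000 nM

Compound 3 is level with compound 1, and the two together give the highest numbers of the three, while compound 2 sits lower by a 5.0-fold higher number from compound 2 to compound 3 (0.70 log units; beyond the scatter). Compound 4, `CCOC(=O)COc1ccc2c(=O)cc(-c3cc(C(C)(C)C)c(O)c(C(C)(C)C)c3)oc2c1`, differs from compound 3 by hydrogen in place of propyl on a saturated chain carbon, two bonds along the chain from an oxygen next to a carbonyl group; read a little further out, the change is pentyl to ethyl.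

For the measured compounds named here, two measured steps bear on this. Taking away the chain on the oxygen on the aromatic ring gave a 5.0-fold lower number from compound 1 to compound 2 (0.70 log units; beyond the scatter), and exchanging that chain for the pentyloxycarbonyl chain gave no change at the digits printed from compound 1 to compound 3 (within the scatter). Shorter chains at this end of the molecule have so far gone with lower numbers, but only one such step is known, so the expected step for compound 4 is a small one, a 1.7-fold lower number from compound 3 to compound 4 (0.22 log units; within the scatter), pointing downward. The estimate for compound 4 is therefore 3000 nM, with a range from 1000 nM to 8000 nM.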

Compound 4, half-maximal inhibitory concentration: 3000 nM
Beside the measured number, compound 4's estimate shows no gap at the digits printed; the measured number falls inside the stated range.
By their numbers in this assay, from the lowest: compound 2; then compounds 4, 1 and 3 (each within the scatter of the next).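

Cutting the ester chain from pentyl to ethyl gives a 1.7-fold lower number from compound 3 to compound 4 (0.22 log units; within the scatter), so at this position the shortening cannot be told apart from no change in this assay. Ethoxycarbonyl in place of pentyl reads the same way, with a 1.7-fold lower number from compound 1 to compound 4 (0.22 log units; within the scatter), whereas ethoxycarbonyl in place of hydrogen still gives a 3.0-fold higher number from compound 2 to compound 4 (0.48 log units; beyond the scatter), so even the shorter ester stays clearly separated from the smallest group on this oxygen. No measurement shown here offers an explanation for these steps.

The compounds shown leave open whether a longer chain than pentyl on the ester would give a step beyond the scatter. They also leave open how a carboxylic acid or an amide in place of the ester would compare with compound 2.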